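A few compounds are considered here, and "the series" means these few. Any claim that something is new, unique, unknown or untested is made for them only; others in the source may bear on it.

Compound 1 `Cc1nc(COc2ccc(/C=C3\SC(=O)NC3=O)cc2)cs1`: in a functional assay on the whole organism (strain Wistar) with Rattus norvegicus as the target, with a stated time of 15 days, at a dose of 3 mg/kg by the oral route (a higher number here means a stronger effect of the compound at the dose given, a lower number a weaker effect), compound 1 gives 18.6%.
Compound 2 `O=C1NC(=O)/C(=C/c2ccc(OCCSc3nnc(-c4ccccc4)[nH]3)cc2)S1`: compound 2 gives 18.6%.
Compound 3 `Cc1ccc(-c2nnc(SCCOc3ccc(/C=C4\SC(=O)NC4=O)cc3)[nH]2)cc1`: compound 3 gives 25.2%.

Compound 3 carries the highest of the three numbers, but the gap to compound 1 and the gap to compound 2 are each within the scatter, so no order among the three can be read from these values. Going by the values given here, the single step between compounds differing in one place, a number 6.6 percentage points higher from compound 2 to compound 3 (within the scatter), is likewise within the scatter; it concerns the same aromatic carbon of the five-membered ring that is altered below.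

Compound 4 `O=C1NC(=O)/C(=C/c2ccc(OCCSc3nnc(-c4ccccc4[N+](=O)[O-])[nH]3)cc2)S1` is the next compound. Relative to compound 3 the change is 2-nitrophenyl in place of 4-methylphenyl on an aromatic carbon.

Among the compounds with values here, the only measured step that bears on this position is the one from compound 2 to compound 3, and it did not move the read-out beyond the scatter. Within the data shown here, the group now entering is larger and of a different kind than anything tested at this carbon, so no measured step shows its effect, and the expectation rests on the flat result at the same place. The step expected in this assay is therefore none beyond the scatter, a number 5.2 percentage points lower from compound 3 to compound 4 (within the scatter). Compound 4 is estimated at 20%, with a range from 8% to 32%.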

Compound 4, a percentage reported as activity, at one dose (the size of the read-out at that dose, not a potency): 19.8%
Beside the measured number, compound 4's estimate is 0.2 percentage points above it, within the range that was stated.
By their numbers in this assay, from the lowest: compounds 1, 2, 4 and 3 (each within the scatter of the next).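

Working notes on the aryl group held by the aromatic carbon of the five-membered aromatic ring with 3 nitrogen: in this assay, exchanging 4-methylphenyl for 2-nitrophenyl, which brings 2 hydrogen-bond acceptors where the leaving group has 0, gives a number 5.4 percentage points lower from compound 3 to compound 4 (within the scatter) and so does not separate the two groups. Measured against the unsubstituted phenyl group, nitro in place of hydrogen gives a number 1.2 percentage points higher from compound 2 to compound 4 (within the scatter), which, read with a number 6.6 percentage points higher from compound 2 to compound 3 (within the scatter), shows that phenyl, 4-methylphenyl and 2-nitrophenyl at this carbon cannot be told apart by this read-out at the single dose used, a statement limited to compounds 2, 3 and 4. No independent measurement bears on why the read-out stays level across these three groups.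

Still open, from the compounds shown here alone, is whether 4-nitrophenyl would match 2-nitrophenyl, and whether an amine or a carboxylic acid on the phenyl ring would carry the read-out beyond the scatter. Also open, going by these compounds, is whether a longer chain between the ring sulfur and the shared core would change the picture that the aryl group alone leaves flat.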